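One Fluoro on the 2-Phenylethenyl Group of Compound 3

This account rests on a few compounds, and the source may have more. Where it says the series, first, only, none or still open, it means among the compounds named here.

Three compounds that share a core and differ in the group on a carbonyl carbon have been measured in an ADME assay on HepG2 2.2.15 cells (Homo sapiens) for cytotoxicity; a higher number here means that more compound is tolerated, a lower number that less compound is tolerated. Compound 1 `CC(=O)N1CCC(C(=O)OCCc2c(-c3ccccc3Cl)c3cc(Cl)ccc3[nH]c2=O)CC1` carries 1-acetylpiperidin-4-yl and gives 82000 nM. Compound 3 `O=C(/C=C/c1ccccc1)OCCc1c(-c2ccccc2Cl)c2cc(Cl)ccc2[nH]c1=O` carries 2-phenylethenyl and gives 230000 nM, the higher of the two actual numbers. Compound 2 `O=C(OCCc1c(-c2ccccc2Cl)c2cc(Cl)ccc2[nH]c1=O)c1cccs1` carries thiophen-2-yl and reads > 1700000 nM, which is a limit of this assay and not a number.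

Compound 4 `O=C(/C=C/c1cccc(F)c1)OCCc1c(-c2ccccc2Cl)c2cc(Cl)ccc2[nH]c1=O` departs from compound 3 in one place: fluoro in place of hydrogen on an aromatic carbon, with fluoro in place of hydrogen on an aromatic carbon. Among the measured compounds shown here, no measured step makes this kind of exchange. All three replace the entire group on the carbonyl carbon: a 2.8-fold higher number from compound 1 to compound 3 (0.45 log units; beyond the scatter) is modest, an at least 7.3-fold lower number from compound 2 to compound 3 (0.86 log units; beyond the scatter) is at least modest, and an at least 20-fold higher number from compound 1 to compound 2 (1.31 log units; beyond the scatter) is large. They bear on the question only indirectly, showing that whole-group swaps can move the number. The present change is far smaller than those swaps, so no shift beyond the scatter is expected, in either direction. The expected step is a 1.1-fold higher number from compound 3 to compound 4 (0.04 log units; within the scatter). For compound 4 the estimated value is 250000 nM, with an expected range of 100000 nM to 600000 nM.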

Compound 4, half-maximal cytotoxic concentration: > 1600000 nM
Compound 4 ended at the assay's limit (the forecaster's own chance of this, stated with the estimate: 10%); middle value at least 6.4-fold (0.80 log units) away from the limit.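

In this assay, a single fluoro on an aromatic carbon of the 2-phenylethenyl group, meta to a large group, moves the number on its own, with an at least 6.9-fold higher number from compound 3 to compound 4 (0.84 log units; beyond the scatter). Until now only exchanges of the whole group on the carbonyl carbon had produced shifts beyond the scatter, yet this one heavy atom also leaves a large step against the acetylated piperidine, with an at least 19-fold higher number from compound 1 to compound 4 (1.29 log units; beyond the scatter). The step between compound 2 and compound 4 cannot be read, because each of the two stands at a limit of this assay and not at a number: the limit of > 1600000 nM in this assay, at which 1 of the 4 values shown sits, and the limit of > 1700000 nM in this assay, at which 1 of the 4 values shown sits.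

The compounds shown leave open whether a chloro, a methoxy or an amine on this same carbon would do what fluoro does here, and whether fluoro on another carbon of that ring would do the same. As far as these compounds go, they also give no actual number for compound 4, so the full size of the change from compound 3 remains unknown.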